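The source may report more compounds than this note shows. Statements on the series, on what has been measured and on what is new or still open speak of the compounds shown alone.

In a functional assay on muscle tissue for agonist activity at histamine H2 receptor (Cavia porcellus) (on this read-out higher numbers stand for larger maximal responses and lower numbers for smaller maximal responses), compound 2 `N=C(NCCCc1c[nH]cn1)NCCC(c1ccc(C(F)(F)F)cc1)c1ccccn1` gives 0.9. Compound 1 `N=C(NCCCc1c[nH]cn1)NCCC(c1ccc(Cl)cc1)c1ccccn1` gives 0.8, and a number 0.10 higher from compound 1 to compound 2 (within the scatter) is within the scatter, so the two compounds cannot be told apart on this read-out. Compound 3 `N=C(NCCCc1c[nH]cn1)NCCC(c1cccc(C(F)(F)F)c1)c1ccccn1` differs from compound 2 by 3-(trifluoromethyl)phenyl in place of 4-(trifluoromethyl)phenyl on a saturated chain carbon bound to an aromatic carbon and a saturated chain carbon. Within the data shown here, no measured step moves a group to another place on its ring; the only step known, a number 0.10 higher from compound 1 to compound 2 (within the scatter), swaps one group for another and stays within the scatter. A step of no change at the digits printed from compound 2 to compound 3 (within the scatter) is therefore expected, none beyond the scatter. Compound 3 is estimated at 0.9, between 0.7 and 1.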

Compound 3, intrinsic activity: the largest response reached, as a fraction of the reference agonist's: 0.7
Compound 3: middle estimate off by 0.20, on the high side; low and high end bracket the measured number.
By their numbers in this assay, from the lowest: compounds 3, 1 and 2 (each within the scatter of the next, the first and the last beyond it).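

In this assay, among these compounds, the swap of 4-(trifluoromethyl)phenyl for 3-(trifluoromethyl)phenyl gives a number 0.20 lower from compound 2 to compound 3 (beyond the scatter) and is the first measured step beyond the scatter, so with the same atoms, the place of the trifluoromethyl group on the phenyl ring can matter here. Replacing 4-chlorophenyl with 3-(trifluoromethyl)phenyl gives a number 0.10 lower from compound 1 to compound 3 (within the scatter) and so separates nothing. No available measurement explains why the place of the group matters. Going by these compounds, whether a chloro group responds to the same move stays open, as does the effect of an amine or a carboxylic acid on this phenyl ring.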